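From 1,4-dioxan-2-yl to oxolan-2-yl: an expected rise

The source may hold more compounds than are shown below. What is called first, only, known or untested is meant among the compounds shown, and "the series" means these compounds.

Values in a physicochemical assay for lipophilicity, read by HPLC, measured as octanol-water partition, at pH 7.4 (a higher number here means a more lipophilic compound, a lower number a more polar compound), for the three measured compounds:
Compound 1 `CC1(C)CO[C@@H]1CN([C@H](CCC(F)(F)F)C(N)=O)S(=O)(=O)c1ccc(Cl)cc1` gives 3.9
Compound 2 `NC(=O)[C@@H](CCC(F)(F)F)N(CC1CCOCC1)S(=O)(=O)c1ccc(Cl)cc1` gives 3.5
Compound 3 `NC(=O)[C@@H](CCC(F)(F)F)N(C[C@H]1COCCO1)S(=O)(=O)c1ccc(Cl)cc1` gives 2.75

Compound 3 gives 2.75 as the lowest of the three numbers, beyond the scatter from both others. Compound 4 `NC(=O)[C@@H](CCC(F)(F)F)N(C[C@@H]1CCCO1)S(=O)(=O)c1ccc(Cl)cc1` has not yet been measured and differs from compound 3 in one place: oxolan-2-yl in place of 1,4-dioxan-2-yl on a saturated chain carbon bound to a sulfonamide nitrogen is the whole of the change. For the measured compounds named here, no measured step makes this exact swap. Two steps ending on 1,4-dioxan-2-yl bear on it, the modest a number 0.75 log units lower from compound 2 to compound 3 (beyond the scatter) and the large a number 1.15 log units lower from compound 1 to compound 3 (beyond the scatter) and both go downward. Leaving that group is therefore expected to bring a modest rise in this assay and no more than the smaller of those steps. The expected change is a number 0.45 log units higher from compound 3 to compound 4 (beyond the scatter) in this estimate. Compound 4 is estimated at 3.2 within a range from 2.85 to 3.55 for now.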

Compound 4, distribution coefficient: 3.5
Beside the measured number, compound 4's estimate is 0.30 log units below it; the measured number falls inside the stated range.
By their numbers in this assay, from the lowest: compound 3; then compounds 2 and 4 (each within the scatter of the next); then compound 1.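

In this assay the swap to oxolan-2-yl gives a number 0.75 log units higher from compound 3 to compound 4 (beyond the scatter) and so sets 1,4-dioxan-2-yl apart from this group on a saturated chain carbon bound to a sulfonamide nitrogen. The five-membered oxolan-2-yl and the oxan-4-yl group cannot be told apart here, the step reading no change at the digits printed from compound 2 to compound 4 (within the scatter) in this comparison. The 3,3-dimethyloxetan-2-yl group remains apart from oxolan-2-yl, with a number 0.40 log units lower from compound 1 to compound 4 (beyond the scatter) as the step. The compounds shown leave open where a piperidin-4-yl ring or a carboxylic acid at this place would fall. No measured evidence explains any of these differences.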